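A few compounds are considered here, and "the series" means these few. Any claim that something is new, unique, unknown or untested is made for them only; others in the source may bear on it.

Compound 3 `CC(=O)OCCOCn1cnc2c(Cl)nc(Cl)nc21` gives 10 ug/mL in a functional assay (Oryctolagus cuniculus) for inhibition (on this read-out lower numbers stand for stronger inhibition and higher numbers for weaker inhibition), the lowest number among the three measured compounds. Compound 1 `Nc1nc(Cl)c2ncn(COCCO)c2n1` gives 50 ug/mL, and compound 2 `CC(=O)OCCOCn1cnc2c(Cl)ncnc21` gives 60 ug/mL; the gaps from compound 3 to each of them lie beyond the scatter. Going by the values given here, one measured step bears on the carbon now in question: a 6.0-fold lower number from compound 2 to compound 3 (0.78 log units; beyond the scatter), a modest gain. Compound 4 `CC(=O)OCCOCn1cnc2c(Cl)nc(N)nc21` differs from compound 3 by amino in place of chloro on an aromatic carbon. Among the compounds with values here, compound 1 already carries an amino group at that carbon, though with a different side chain, and no step to compound 3 is counted for it; the two values alone show compound 1 standing well above compound 3. Taken together, the gain on putting chloro in place of hydrogen and the higher number of compound 1 point to weaker inhibition for compound 4. The expected step is a 5.0-fold higher number from compound 3 to compound 4 (0.70 log units; beyond the scatter), a weakening, since compound 1 with its amino group gives 50 ug/mL. Compound 4 is therefore estimated at 50 ug/mL, within a range from 15 ug/mL to 160 ug/mL.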

Compound 4, concentration for 50% inhibition: 55 ug/mL
Compound 4: the middle estimate sits 1.1-fold (0.04 log units) below what was measured; the measured number falls inside the stated range.
By their numbers in this assay, from the lowest: compound 3; then compounds 1, 4 and 2 (each within the scatter of the next).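

In this assay the change at the aromatic carbon between two ring nitrogen atoms gives a 5.5-fold higher number from compound 3 to compound 4 (0.74 log units; beyond the scatter) and so amino does not share the gain seen with chloro at this carbon. Amino in place of hydrogen at the same carbon gives a 1.1-fold lower number from compound 2 to compound 4 (0.04 log units; within the scatter) and acetyl in place of hydrogen on the oxygen gives a 1.1-fold higher number from compound 1 to compound 4 (0.04 log units; within the scatter) so that, within this set, only chloro at this carbon separates from the others, and with amino there the acetyl makes no difference beyond the scatter. Nothing on hand explains why chloro and amino differ at this carbon.

From the compounds shown here alone, whether a methyl, a methoxy group or a bromo at this carbon would keep the low number of compound 3 remains open. Also open, going by these compounds, is whether the acetyl would make as little difference with chloro at this carbon.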